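The source may report more compounds than this note shows. Statements on the series, on what has been measured and on what is new or still open speak of the compounds shown alone.

Of the compounds shown here, two from this series have been tested in an ADME assay on NIH3T3 cells (Mus musculus) for cytotoxicity, read by MTT assay, with a stated time of 24 h; on this read-out higher numbers stand for weaker inhibition and lower numbers for stronger inhibition. Compound 1 `O=C(CSc1nnc(-c2ccncc2)o1)N/N=C/c1ccccc1` gives 167000 nM in this assay. Among the compounds with values here, compound 2 `O=C(CSc1nnc(-c2ccncc2)o1)N/N=C/c1ccc(Br)cc1` gives 169000 nM in this assay, and the only step so far, a 1.0-fold higher number from compound 1 to compound 2 (0.01 log units; within the scatter), introduces bromo in place of hydrogen on an aromatic carbon. On the two numbers available, compound 2 stands highest, though its gap to compound 1 is within the scatter, so no order between them can be claimed.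

Compound 3 `O=C(CSc1nnc(-c2ccncc2)o1)N/N=C/c1cc(Br)ccc1O` has not yet been measured. Its difference from compound 2 is 5-bromo-2-hydroxyphenyl in place of 4-bromophenyl on a carbon with a double bond to nitrogen. Within the data shown here, the single measured step does not probe a hydroxyl and bears on this change only loosely, and it was itself within the scatter; the expectation for this assay is therefore a step of a 1.0-fold lower number from compound 2 to compound 3 (0.01 log units; within the scatter), that is, none beyond the scatter. Compound 3 is accordingly estimated at 165000 nM, with a range from 80000 nM to 330000 nM.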

Compound 3, half-maximal inhibitory concentration: 156000 nM
For compound 3 the middle estimate is 1.1-fold (0.02 log units) above the measured one; the range from low to high includes it.
By their numbers in this assay, from the lowest: compounds 3, 1 and 2 (each within the scatter of the next).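

Within the data shown here, the hydroxyl of 5-bromo-2-hydroxyphenyl is the first hydrogen-bond donor and acceptor seen in this aryl group, on a carbon with a double bond to nitrogen, and in this assay it brings no step beyond the scatter: a 1.1-fold lower number from compound 2 to compound 3 (0.03 log units; within the scatter) and a 1.1-fold lower number from compound 1 to compound 3 (0.03 log units; within the scatter). Phenyl, 4-bromophenyl and 5-bromo-2-hydroxyphenyl therefore cannot be told apart at this position, and no order among the three compounds can be drawn. No measurement here offers an explanation for this result.

From the compounds shown here alone, the change from compound 2 to compound 3 alters the bromo placement and adds the hydroxyl together, so the share of each stays open. Going by these compounds, it is also open whether an amine or a carboxylic acid on this ring would give a step beyond the scatter.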